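The compounds below may be only part of what the source reports. "The series", "measured", "known", "first", "only" and "open" are said of these compounds alone.

Measured so far in a functional assay on microsomes from liver for antagonist activity at Substance-P receptor (Rattus norvegicus); on this read-out lower numbers stand for stronger inhibition and higher numbers for weaker inhibition:
compound 1 `C[C@@H](O[C@H]1CCCN[C@H]1c1ccccc1)c1cc(Cl)cc(Cl)c1` gives 0.91 nM
compound 2 `C[C@H](O[C@H]1CCCN[C@H]1c1ccccc1)c1cc(Cl)cc(Cl)c1` gives 85 nM

Compound 1 stands at the lowest of the two numbers in this assay. Among the measured compounds shown here, the only measured step is a 93-fold higher number from compound 1 to compound 2 (1.97 log units; beyond the scatter), a large step that rests entirely on (the fact that compounds 1 and 2 differ only in the configuration as drawn); the two compounds carry the same atoms and bonds throughout.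

Compound 3 `C[C@@H](O[C@H]1CCCN(Cc2n[nH]c(O)n2)[C@H]1c1ccccc1)c1cc(Cl)cc(Cl)c1` differs from compound 1 by (5-hydroxy-1H-1,2,4-triazol-3-yl)methyl in place of hydrogen on an amine nitrogen in a ring. The measured step concerns configuration alone and says nothing about a substituent on the ring nitrogen, so no measured step bears on the change from compound 1 to compound 3, and no direction can be taken from the numbers shown. The estimate for compound 3 in this assay is therefore set close to the number of compound 1, at 1.5 nM, with a wide range from 0.3 nM to 8 nM. The step of a 1.6-fold higher number from compound 1 to compound 3 (0.22 log units; within the scatter) that this estimate implies is expected to stay within the scatter, with the width of the range carrying the uncertainty.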

Compound 3, half-maximal inhibitory concentration: 0.09 nM
Compound 3: the middle estimate sits 17-fold (1.22 log units) above what was measured; the whole stated range lies above it.
By their numbers in this assay, from the lowest: compound 3; then compound 1; then compound 2.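

The amine nitrogen in the ring need not stay unsubstituted: in this assay, (5-hydroxy-1H-1,2,4-triazol-3-yl)methyl in place of hydrogen gives a 10-fold lower number from compound 1 to compound 3 (1.00 log units; beyond the scatter), a step beyond the scatter. This position, next to the ring atom that bears a phenyl group, therefore accepts a five-membered aromatic ring with 3 hetero atoms on a methyl link and shows stronger inhibition, something the earlier configurational step could not show. Nothing measured here gives the reason for this gain.

On these data alone, whether the gain needs this ring or any substituent on this nitrogen would do stays open: a plain methyl, a longer chain, an amine or a carboxylic acid at the same nitrogen would separate the two. Also open, as far as these compounds go, is whether the configuration drawn in compound 2 would cost as much with this group present.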